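Cytotoxicity in J774 cells: a bromo-to-methoxyphenoxy exchange

A few compounds are considered here, and "the series" means these few. Any claim that something is new, unique, unknown or untested is made for them only; others in the source may bear on it.

The series shares one core carrying an ethyl ester and an ethyl group, compared in an ADME assay on J774 cells (Mus musculus) for cytotoxicity, read by MTT assay, with a stated time of 48 h; on this read-out higher numbers stand for weaker inhibition and lower numbers for stronger inhibition. Compound 1 `CCOC(=O)c1cc2c(n1CC)C(=O)C(Oc1ccc(Cl)cc1)=CC2=O` has no number in this assay, its entry being "not determined" (no result reported). Compound 3 `CCOC(=O)c1cc2c(n1CC)C(=O)C(Br)=CC2=O` likewise has no number in this assay, its entry being "not determined" (no result reported). Among the measured compounds shown here, compound 2 `CCOC(=O)c1cc2c(n1CC)C(=O)C(Oc1ccccc1)=CC2=O` is the only member with a value, and in this assay compound 2 gives 22000 nM. Compound 4 `CCOC(=O)c1cc2c(n1CC)C(=O)C(Oc1ccc(OC)cc1)=CC2=O` remains to be measured. Compound 4 differs from compound 3 by 4-methoxyphenoxy in place of bromo on a double-bonded ring carbon. With no figure for compound 3, the size of the step cannot be read from the data, and no step beyond the usual scatter can be claimed in either direction. Compound 4 is expected to give about 20000 nM in this assay, within 7000 nM to 60000 nM, because compound 2 gives 22000 nM.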

Compound 4, half-maximal inhibitory concentration: 12500 nM
The estimate for compound 4 lay 1.6-fold (0.20 log units) above the measured number, within the range that was stated.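

In this assay, methoxy in place of hydrogen on an aromatic carbon of the phenoxy group gives a 1.8-fold lower number from compound 2 to compound 4 (0.25 log units; within the scatter), so compound 2 and compound 4 cannot be told apart. This position therefore now has two aryl ethers with readable values, and this change leaves the read-out within the scatter. The step from bromo to 4-methoxyphenoxy cannot be read, as compound 3 has no number, and no measurement at hand explains the result.

The compounds shown leave open how an amine or a carboxylic acid in place of the phenoxy group at this double-bonded ring carbon would read in this assay. They also leave open whether a chloro group on the phenoxy ring, as in compound 1, would read alongside these values.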